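The source may report more compounds than this note shows. Statements on the series, on what has been measured and on what is new or still open speak of the compounds shown alone.

Three compounds share one core and differ only in the aromatic ring at the far end of the chain. Compound 1 `O=C(CCCCCCc1ccccc1Cl)c1ncc(-c2ccccn2)o1` gives 1.9 nM in an assay for inhibition of Fatty-acid amide hydrolase 1 (Rattus norvegicus); on this read-out lower numbers stand for stronger inhibition and higher numbers for weaker inhibition. Compound 2 `CS(=O)(=O)c1cccc(CCCCCCC(=O)c2ncc(-c3ccccn3)o2)c1` gives 1.3 nM in this assay. Compound 3 `Nc1ccc(CCCCCCC(=O)c2ncc(-c3ccccn3)o2)cc1` gives 3 nM in this assay, the highest of the three numbers; its gap to compound 1 is within the scatter, its gap to compound 2 lies beyond it.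

Compound 4 `CSc1cccc(CCCCCCC(=O)c2ncc(-c3ccccn3)o2)c1` is not yet measured. It differs from compound 3 by 3-(methylsulfanyl)phenyl in place of 4-aminophenyl on a saturated chain carbon, six bonds along the chain from a carbonyl carbon. Within the data shown here, the only measured step at this position, a 1.6-fold higher number from compound 1 to compound 3 (0.20 log units; within the scatter), shows that exchanging one ring for another here left the number essentially unchanged. Compound 2, which also carries a ring substituted at the same position of the phenyl ring as compound 4, sits at the low end of the narrow band. A step of no more than scatter size is therefore expected from compound 3 to compound 4, namely a 1.7-fold lower number from compound 3 to compound 4 (0.22 log units; within the scatter). Compound 4 is expected to give about 1.8 nM in this assay, in a range from 0.7 nM to 4.5 nM.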

Compound 4, inhibition constant: 4.2 nM
The estimate for compound 4 lay 2.3-fold (0.37 log units) below the measured number, within the range that was stated.
By their numbers in this assay, from the lowest: compounds 2, 1, 3 and 4 (each within the scatter of the next, the first and the last beyond it).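

Among these compounds, changing only the sulfur group, methylsulfanyl in place of methylsulfonyl on an aromatic carbon, gives a 3.2-fold higher number from compound 2 to compound 4 (0.51 log units; beyond the scatter), the first look at a single substituent on this ring and a modest but real effect. Exchanging whole rings gives mixed results: a 1.4-fold higher number from compound 3 to compound 4 (0.15 log units; within the scatter), whereas a 2.2-fold higher number from compound 1 to compound 4 (0.34 log units; beyond the scatter), so the far end of the chain tolerates much but does not leave the number entirely fixed. Nothing available explains these differences.

The compounds shown leave open how methylsulfinyl, which lies between the two sulfur groups, would read in this assay. They also leave open whether a carboxylic acid on the ring or a longer chain would keep the numbers in this narrow band.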